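Shortening a side chain on a rat aorta sulfone series

The compounds below may be only part of what the source reports. "The series", "measured", "known", "first", "only" and "open" are said of these compounds alone.

Compound 1 `CCCCc1cn2ccccc2c1S(=O)(=O)c1ccc(OCCCN(CCCC)CCCC)cc1` is measured in a functional assay (aorta) with Rattus norvegicus as the target; on this read-out higher numbers stand for weaker inhibition and lower numbers for stronger inhibition; compound 1 gives 284 nM. Compound 3 `CCCCN(CCCC)CCCOc1ccc(S(=O)(=O)c2c(CCC)cn3ccccc23)cc1` differs from it by one change hydrogen in place of methyl on a saturated chain carbon, three bonds along the chain from an aromatic carbon and in this assay compound 3 gives 54.3 nM; the step of a 5.2-fold lower number from compound 1 to compound 3 (0.72 log units; beyond the scatter). Compound 2 `CCCN(CCC)CCCOc1ccc(S(=O)(=O)c2c(C(C)C)cn3ccccc23)cc1` has a different core, and the difference between the two cores is not broken down here; in this assay compound 2 gives 102 nM. Compound 4 `CCCN(CCC)CCCOc1ccc(S(=O)(=O)c2c(CC)cn3ccccc23)cc1` is not yet measured and differs from compound 2 by hydrogen in place of methyl on a saturated chain carbon bound to an aromatic carbon and a saturated chain carbon. Among the compounds with values here, this is the same kind of change as the one from compound 1 to compound 3, but the place is not the same: there the carbon sat three bonds along the chain from an aromatic carbon, here it is bound to an aromatic carbon and a saturated chain carbon. Because the earlier removal gave a 5.2-fold lower number from compound 1 to compound 3 (0.72 log units; beyond the scatter), a smaller gain is expected, a 1.6-fold lower number from compound 2 to compound 4 (0.20 log units; within the scatter). Compound 4 is estimated at 65 nM, between 25 nM and 200 nM.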

Compound 4, half-maximal inhibitory concentration: 150 nM
Compound 4: the middle estimate sits 2.3-fold (0.36 log units) below what was measured, and the stated range covers the measured number.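

In this assay, trimming isopropyl to ethyl gives a 1.5-fold higher number from compound 2 to compound 4 (0.17 log units; within the scatter), a step too small to read as a real change. The same kind of change therefore does not carry over as a fixed gain from one core to the other: the same change on two cores in this assay, a 5.2-fold lower number (0.72 log units; beyond the scatter) from compound 1 to compound 3 and a 1.5-fold higher number (0.17 log units; within the scatter) from compound 2 to compound 4, 7.7-fold (0.89 log units) apart, beyond the scatter of two such steps. What this does not show is why the two steps differ: the methyl leaves a different place in each pair and the surrounding structures differ as well, and one pair of each kind cannot separate these.

Going by these compounds, it remains open how a methyl or cyclopropyl group in place of the ethyl of compound 4 would read. Also open, on these data alone, is whether trimming isopropyl to ethyl would read the same with butyl chains on the amine.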